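The source may hold more compounds than are shown below. What is called first, only, known or untested is meant among the compounds shown, and "the series" means these compounds.

Measured so far in a functional assay on SK-BR-3 cells (Homo sapiens) for antiproliferative activity, read by MTT assay, with a stated time of 72 h; a higher number here means a weaker inhibitor, a lower number a stronger inhibitor:
compound 1 `C/C=C1/[C@H](O[C@@H]2O[C@H](CO)[C@@H](O)[C@H](O)[C@H]2O)OC=C(C(=O)OC)[C@H]1CC(=O)OCCc1ccc(OC)c(OC)c1`: > 15000 nM
compound 2 `C/C=C1/[C@H](O[C@@H]2O[C@H](CO)[C@@H](O)[C@H](O)[C@H]2O)OC=C(C(=O)OC)[C@H]1CC(=O)OCCc1ccc(OC)cc1`: > 20000 nM

The value of compound 1 in this assay is a limit of the assay, not a number. The value of compound 2 in this assay is likewise a limit. The step that the two limits leave unreadable from compound 1 to compound 2 is therefore unreadable, since both ends rest on limits (the limit of > 15000 nM in this assay, at which 1 of the 2 values shown sits, and (the limit of > 20000 nM in this assay, at which 1 of the 2 values shown sits)). Compound 2 thus stands at a limit of this assay with no measured number of its own.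

Compound 3 `C/C=C1/[C@H](O[C@@H]2O[C@H](CO)[C@@H](O)[C@H](O)[C@H]2O)OC=C(C(=O)OC)[C@H]1CC(=O)OCc1ccccc1` differs from compound 2 by phenyl in place of 4-methoxybenzyl on a saturated chain carbon bound to an oxygen next to a carbonyl group. Among the compounds with values here, no measured step bears on this change; the single measured step concerns a different change and is itself unreadable. No shift beyond the scatter is expected in this assay, and the expected step of a number no higher from compound 2 to compound 3 (the limit leaves the size open) is accordingly set at nothing. Compound 3 is expected to remain at a limit, with an estimate of 20000 nM and a range from 5000 nM to 80000 nM.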

Compound 3, half-maximal inhibitory concentration: > 15000 nM
Compound 3 ended at the assay's limit; the forecaster's own chance of this, stated with the estimate: 80%; the middle value lies beyond the limit too.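

In this assay compound 3 gives > 15000 nM, a limit of the assay and not a number. The steps from compound 1 and compound 2 to compound 3 cannot be read: all three values are limits. From the compounds shown here alone, whether these changes shift antiproliferative activity at all stays open.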